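A few compounds are considered here, and "the series" means these few. Any claim that something is new, unique, unknown or untested is made for them only; others in the source may bear on it.

Measured so far: compound 1 `Cn1c(=O)c(=O)n(C2CCCC2)c2nc(N/N=C/c3ccc(F)c(Cl)c3)ncc21`, 8550 nM; compound 2 `Cn1c(=O)c(=O)n(C2CCCC2)c2nc(N/N=C/c3ccc(C(F)(F)F)cc3)ncc21`, 23600 nM.

In a functional assay on PC-3 cells (Homo sapiens) for antiproliferative activity, read by MTT assay (on this read-out lower numbers stand for stronger inhibition and higher numbers for weaker inhibition), compound 2 stands highest of the two numbers, with compound 1 as its nearest neighbour. Compound 3 `Cn1c(=O)c(=O)n(C2CCCC2)c2nc(N/N=C/c3cccc(Cl)c3Cl)ncc21` differs from compound 2 by 2,3-dichlorophenyl in place of 4-(trifluoromethyl)phenyl on a carbon with a double bond to nitrogen. Among the measured compounds shown here, the only step that bears on this change is a 2.8-fold higher number from compound 1 to compound 2 (0.44 log units; beyond the scatter), where a dihalogenated phenyl gave way to the trifluoromethyl-bearing one; the present change reverses that exchange, although with a different halogen pattern. A modest decrease is therefore expected, estimated as a 2.1-fold lower number from compound 2 to compound 3 (0.33 log units; beyond the scatter). Compound 3 is estimated at 11000 nM, with a range from 4000 nM to 30000 nM.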

Compound 3, half-maximal inhibitory concentration: 17200 nM
Beside the measured number, compound 3's estimate is 1.6-fold (0.19 log units) below it; low and high end bracket the measured number.
By their numbers in this assay, from the lowest: compounds 1, 3 and 2 (each within the scatter of the next, the first and the last beyond it).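

In this assay the 2,3-dichlorophenyl group cannot be separated from either of the other two groups, with a 1.4-fold lower number from compound 2 to compound 3 (0.14 log units; within the scatter) and a 2.0-fold higher number from compound 1 to compound 3 (0.30 log units; within the scatter) as the two new steps. At this place, on a carbon with a double bond to nitrogen, only a 2.8-fold higher number from compound 1 to compound 2 (0.44 log units; beyond the scatter) remains a step clearly beyond the scatter, so exchanging one halogen-bearing phenyl for another need not shift the number measurably. No measurement on hand accounts for these numbers.

On these data alone, whether a phenyl carrying an amine or a carboxylic acid would give a clearly different number stays open. So does the effect of replacing the phenyl with a longer alkyl chain at this place.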